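Methyl Additions in a Thiourea Series and Cytotoxicity

This account rests on a few compounds, and the source may have more. Where it says the series, first, only, none or still open, it means among the compounds named here.

Compound 1 `CNC(=S)Nc1cccc(OCCCCCc2ccccc2)c1` and compound 2 `CCNC(=S)Nc1cccc(OCCCCCc2ccccc2)c1` share one core; compound 3 `CC(CCOc1ccccc1)CCOc1cccc(NC(N)=S)c1` carries another chain, and the difference between the core of compound 1 and the core of compound 3 is not broken down here. In an ADME assay on Ava5 cells (Homo sapiens) for cytotoxicity (on this read-out lower numbers stand for higher toxicity in this test and higher numbers for lower toxicity in this test), compound 1 gives only a limit of the assay, > 50000 nM. In this assay compound 2 likewise gives only a limit, > 50000 nM. In this assay compound 3 also gives only a limit, > 50000 nM. The change from compound 1 to compound 2 is methyl in place of hydrogen on a saturated chain carbon bound to an amide-type nitrogen, and the step it made is a step that the two limits leave unreadable from compound 1 to compound 2. All three values sit at the limit of > 50000 nM in this assay, at which 3 of the 3 values shown sit.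

Compound 4 `CC(C)(CCOc1ccccc1)CCOc1cccc(NC(N)=S)c1`, not yet measured, differs from compound 3 by methyl in place of hydrogen on a saturated chain carbon bound to three saturated chain carbons. Among the compounds with values here, this is the same kind of change as the one between compound 1 and compound 2, though the place is not the same: there the methyl enters on a saturated chain carbon bound to an amide-type nitrogen, here on a saturated chain carbon bound to three saturated chain carbons. The step from compound 3 to compound 4 in this assay is expected to be a step that the limit leaves unreadable from compound 3 to compound 4, which rests on the limit of > 50000 nM in this assay, at which 3 of the 3 values shown sit, and on the earlier step that the two limits leave unreadable from compound 1 to compound 2. Compound 4 is therefore estimated to give 60000 nM in this assay, most likely again as a limit rather than a number.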

Compound 4, half-maximal cytotoxic concentration: 13000 nM
The estimate for compound 4 lay 4.6-fold (0.66 log units) above the measured number, and the stated range ends above it.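

In this assay, methyl in place of hydrogen on a saturated chain carbon bound to three saturated chain carbons gives an at least 3.8-fold lower number from compound 3 to compound 4 (0.58 log units; beyond the scatter) and so, on this read-out, goes with higher toxicity in this test. This shows that one methyl can bring a readable change on this core, but it does not show that the same change would do so on the core of compound 1, where the methyl also enters at another place, on a saturated chain carbon bound to an amide-type nitrogen. The step between compound 1 and compound 2 cannot be read, so the series offers no second size to set beside this one, and neither a carry-over between the cores nor a failure to carry over can be claimed: the limit of > 50000 nM in this assay, at which 3 of the 4 values shown sit.

The compounds shown leave open whether the lower number belongs to methyl in particular or would also appear with an ethyl group or a hydroxyl group on that same saturated chain carbon. They also leave open what a methyl on a saturated chain carbon bound to three saturated chain carbons would do on the core of compound 1, where such a comparison would test the change at one place on both cores.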